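The compounds below may be only part of what the source reports. "The series", "measured", "known", "first", "only" and "open" are said of these compounds alone.

Compound 1 `ClCCc1c(Cl)nc2ccc(Cl)cc2c1-c1ccccc1Cl` — in an ADME assay on HepG2 2.2.15 cells (Homo sapiens) for cytotoxicity (a lower number here means that less compound is tolerated, a higher number that more compound is tolerated), compound 1 gives > 1400000 nM, which is a limit of the assay and not a number.
Compound 2 `COc1nc2ccc(Cl)cc2c(-c2ccccc2Cl)c1CCO` — compound 2 gives 141000 nM.
Compound 3 `OCCc1c(OCc2c(F)cccc2F)nc2ccc(Cl)cc2c1-c1ccccc1Cl` — compound 3 gives 109000 nM.

Compound 3 thus has the lowest of the two numbers, with compound 2 nearest; the step of a 1.3-fold lower number from compound 2 to compound 3 (0.11 log units; within the scatter) lies within the scatter. Compound 4 `OCCc1c(N2CCNCC2)nc2ccc(Cl)cc2c1-c1ccccc1Cl` differs from compound 3 by piperazin-1-yl in place of (2,6-difluorobenzyl)oxy on an aromatic carbon. Within the data shown here, no measured step touches this position with a change of this kind; the only measured step, a 1.3-fold lower number from compound 2 to compound 3 (0.11 log units; within the scatter), concerned the chain on the ether oxygen and was within the scatter. For compound 4 the expected step is therefore a 1.4-fold higher number from compound 3 to compound 4 (0.14 log units; within the scatter), none beyond the scatter. Compound 4 is estimated at 150000 nM, between 50000 nM and 500000 nM.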

Compound 4, half-maximal cytotoxic concentration: < 5000 nM
Compound 4: no number, only a limit; the forecaster's own chance of this, stated with the estimate: 15%; middle value at least 30-fold (1.47 log units) away from the limit.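

At the aromatic carbon next to the ring nitrogen, the group matters in this assay: replacing the ether groups with piperazin-1-yl gives an at least 21-fold lower number from compound 3 to compound 4 (1.33 log units; beyond the scatter) and an at least 28-fold lower number from compound 2 to compound 4 (1.45 log units; beyond the scatter). Compound 4 gives < 5000 nM, which is a limit of the assay and not a number. Methoxy and (2,6-difluorobenzyl)oxy had stayed within the scatter of each other, so the sensitivity of this position appears only with piperazin-1-yl. The compounds shown leave open whether an open-chain amine such as dimethylamino would give a step of similar size. They also leave open how far the true value of compound 4 lies beyond its limit.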